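Carbamate to ester on a shared antiproliferative core

The source may report more compounds than this note shows. Statements on the series, on what has been measured and on what is new or still open speak of the compounds shown alone.

Compound 2 `CC1=CC[C@H](C(C)C)c2cc(C)c(OC(=O)Nc3ccccc3)cc21` gives 100% in a functional assay on U-251 cells (Homo sapiens) for antiproliferative activity, read by sulforhodamine B assay, with a stated time of 48 h, tested at 50 uM (a higher number here means more inhibition at the concentration tested (going by the name of the read-out), a lower number less inhibition), the only numerical result in the set. Compound 1 `Cc1cc2c(C(C)C)ccc(C)c2cc1OC(=O)c1cccc(C(F)(F)F)c1` is recorded there as "not active" (no number reported), a qualitative entry without a number. Compound 3 `CC1=CC[C@H](C(C)C)c2cc(C)c(OC(=O)c3ccccc3)cc21` differs from compound 2 by phenyl in place of anilino on a carbonyl carbon. Among the measured compounds shown here, with no measured pair covering this change, the expectation rests on compound 2 alone, and a step downward beyond the scatter, expected as a number 40 percentage points lower from compound 2 to compound 3 (beyond the scatter), is the more likely outcome. Compound 3 is therefore expected to give 60% in this assay, within a range from 10% to 100%.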

Compound 3, a percentage reported as inhibition, at one concentration (the size of the read-out at that concentration, not a potency): 25.8%
For compound 3 the middle estimate is 34.2 percentage points above the measured one; the measured number falls inside the stated range.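

On the carbonyl carbon of the shared core, replacing anilino with phenyl gives a number 74.2 percentage points lower from compound 2 to compound 3 (beyond the scatter) in this assay, so activity at this position depends strongly on which of these two groups is present. Anilino counts a hydrogen-bond donor and phenyl does not, yet compound 3 still gives 25.8%. No evidence here accounts for the drop. On these data alone, whether a methylamino or benzylamino group on the same carbonyl carbon would match anilino remains open, as does the effect of a chlorine or methoxy group on the anilino ring.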